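The compounds below may be only part of what the source reports. "The series", "measured", "known", "first", "only" and "open" are said of these compounds alone.

Compound 1 `CC(=O)N(C)c1ccc2[nH]c(-c3n[nH]c4ccccc34)cc2n1`, compound 2 `CN(C(=O)C(C)(C)C)c1ccc2[nH]c(-c3n[nH]c4ccccc34)cc2n1` and compound 3 `CN(C(=O)c1ccc(Br)cc1)c1ccc2[nH]c(-c3n[nH]c4ccccc34)cc2n1` share one core and differ only in the group on the carbonyl carbon. In a functional assay on SMMC-7721 cells (Homo sapiens) for antiproliferative activity, read by MTT assay, with a stated time of 72 h (a lower number here means a stronger inhibitor, a higher number a weaker inhibitor), compound 1 gives 23400 nM, compound 2 gives 22200 nM and compound 3 gives 3460 nM. Compound 2 stands second highest of the three numbers: its nearest neighbour is compound 1, with a 1.1-fold lower number from compound 1 to compound 2 (0.02 log units; within the scatter), and its furthest is compound 3, with a 6.4-fold lower number from compound 2 to compound 3 (0.81 log units; beyond the scatter).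

Compound 4 `Cc1ccc(S(=O)(=O)N(C)c2ccc3[nH]c(-c4n[nH]c5ccccc45)cc3n2)cc1` differs from compound 2 in that ((4-methylphenyl)sulfonyl in place of (tert-butyl)carbonyl on a nitrogen on an aromatic ring). Among the compounds with values here, two measured steps bear on this change: a 6.8-fold lower number from compound 1 to compound 3 (0.83 log units; beyond the scatter) and a 6.4-fold lower number from compound 2 to compound 3 (0.81 log units; beyond the scatter) both show that a six-membered aromatic ring of carbon only, in place of a small alkyl group, lowers the number modestly. Within the data shown here, compound 4 likewise brings such a ring, but as a (4-methylphenyl)sulfonyl, and no measured pair covers a sulfonyl in place of a carbonyl. The account therefore expects in this assay a modest lowering, held with less confidence than the measured steps, and the expected step is a 3.7-fold lower number from compound 2 to compound 4 (0.57 log units; beyond the scatter). Compound 4 is estimated at 6000 nM, with a range expected to run from 1500 nM to 24000 nM.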

Compound 4, half-maximal inhibitory concentration: 16300 nM
Estimate against measurement, compound 4: 2.7-fold (0.43 log units) below; measured number inside the range.
By their numbers in this assay, from the lowest: compound 3; then compounds 4, 2 and 1 (each within the scatter of the next).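

In this assay, a six-membered aromatic ring of carbon only does not by itself bring the lowering that compound 3 showed: compound 4 also carries such a ring, yet the exchange on the nitrogen gives only a small step (a 1.4-fold lower number from compound 2 to compound 4 (0.13 log units; within the scatter)) and its number also stays within the scatter of the acetyl compound (a 1.4-fold lower number from compound 1 to compound 4 (0.16 log units; within the scatter)). The gap to the (4-methylphenyl)sulfonyl compound's aryl carbonyl counterpart remains beyond the scatter (a 4.7-fold higher number from compound 3 to compound 4 (0.67 log units; beyond the scatter)), so at this place the ring alone does not set the number, and what accompanies it also counts, although this step changes the sulfonyl for the carbonyl and the methyl for the bromine together. No measurement given here explains this result.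

The compounds shown leave open whether the sulfonyl link or the ring's bromine accounts for the gap, which a (4-bromophenyl)sulfonyl or a (4-methylphenyl)carbonyl group on the same nitrogen would separate. They also leave open how this position responds to a group carrying an amine or a carboxylic acid, or to a longer chain on the carbonyl carbon.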